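Pyridinyl for Furanyl on a Piperidine-Bearing Core

The compounds below may be only part of what the source reports. "The series", "measured", "known", "first", "only" and "open" are said of these compounds alone.

Compound 1 `c1cc(Nc2nccc(-c3cccnc3)n2)cc(OCCn2ccnc2)c1`: 100 nM
Compound 2 `c1cc(Nc2nccc(-c3ccco3)n2)cc(OCCn2ccnc2)c1`: 200 nM
Compound 3 `CC1CCN(c2cccc(Nc3nccc(-c4ccco4)n3)c2)CC1`: 5000 nM

These three compounds were measured in a functional assay for inhibition, with Homo sapiens as the target; a higher number here means a weaker inhibitor, a lower number a stronger inhibitor. Compound 2 and compound 1 differ in one place, (pyridin-3-yl in place of furan-2-yl on an aromatic carbon), and the step is a 2.0-fold lower number from compound 2 to compound 1 (0.30 log units; within the scatter). Compound 3 has the highest number of the three; its core and the core of compound 2 differ in 4-methylpiperidin-1-yl in place of 2-(1H-imidazol-1-yl)ethoxy on an aromatic carbon, a step of a 25-fold higher number from compound 2 to compound 3 (1.40 log units; beyond the scatter). The unmeasured compound 4 `CC1CCN(c2cccc(Nc3nccc(-c4cccnc4)n3)c2)CC1` is reached from compound 3 by pyridin-3-yl in place of furan-2-yl on an aromatic carbon, the same change as from compound 2 to compound 1, at the same place. For compound 4 in this assay a step of a 1.7-fold lower number from compound 3 to compound 4 (0.22 log units; within the scatter) is expected, resting on the earlier step of a 2.0-fold lower number from compound 2 to compound 1 (0.30 log units; within the scatter) that lay within the scatter. Compound 4 is therefore estimated at 3000 nM, with the expected range running from 1200 nM to 8000 nM.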

Compound 4, half-maximal inhibitory concentration: 1200 nM
Compound 4: the middle estimate sits 2.5-fold (0.40 log units) above what was measured, within the range that was stated.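

In this assay putting pyridin-3-yl in place of furan-2-yl gives a 4.2-fold lower number from compound 3 to compound 4 (0.62 log units; beyond the scatter), and this step does not differ from the one seen on the other core: the same change on two cores in this assay, a 2.0-fold lower number (0.30 log units; within the scatter) from compound 2 to compound 1 and a 4.2-fold lower number (0.62 log units; beyond the scatter) from compound 3 to compound 4, 2.1-fold (0.32 log units) apart, within the scatter of two such steps. Putting 4-methylpiperidin-1-yl in place of 2-(1H-imidazol-1-yl)ethoxy gives a 12-fold higher number from compound 1 to compound 4 (1.08 log units; beyond the scatter), and this step likewise holds across the two cores: the same change on two cores in this assay, a 25-fold higher number (1.40 log units; beyond the scatter) from compound 2 to compound 3 and a 12-fold higher number (1.08 log units; beyond the scatter) from compound 1 to compound 4, 2.1-fold (0.32 log units) apart, within the scatter of two such steps. Both changes therefore carried over between the cores within these four compounds, but two cores cannot show that either step would hold on a further core.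

The compounds shown leave open how a thiophen-2-yl or pyridin-4-yl group would compare at the place of the furan-2-yl. They also leave open whether a dimethylamino group on the same ethoxy chain could stand in for the imidazole.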